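Phenyl in Place of Bromo on the Ketone Aryl Ring

The source may hold more compounds than are shown below. What is called first, only, known or untested is meant among the compounds shown, and "the series" means these compounds.

Of the compounds shown here, two have been measured. Compound 1 `COc1ccc(C(=O)CSc2nccc(Nc3cccc(C(C)=O)c3)n2)cc1` gives 35% in a functional assay on UACC-62 cells (Homo sapiens) for inhibition, read by sulforhodamine B assay, with a stated time of 48 h, tested at 10 uM; a higher number here means more inhibition of growth at the concentration tested, a lower number less inhibition of growth. Compound 2 `CC(=O)c1ccc(Nc2ccnc(SCC(=O)c3ccc(Br)cc3)n2)cc1` gives 23% in this assay, the lower of the two numbers; the gap to compound 1 lies beyond the usual scatter of repeated measurements. Going by the values given here, no pair of measured compounds differs in a single place, so nothing measured speaks directly to a single structural exchange.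

Compound 3 `CC(=O)c1ccc(Nc2ccnc(SCC(=O)c3ccc(-c4ccccc4)cc3)n2)cc1` has not been measured. It differs from compound 2 in one place: phenyl in place of bromo on an aromatic carbon. The exchange sits on an aromatic carbon of a six-membered aromatic ring of carbon only, para to a large group, with phenyl taking the place of bromo.

Among the compounds with values here, with no measured step to lean on, the change is expected to move the number only a little, in either direction or not at all beyond the scatter: the expected step of a number 5 percentage points higher from compound 2 to compound 3 (within the scatter) is small and within the usual scatter. Compound 3 is estimated to give 28% in this assay, with a likely range from 10% to 50%.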

Compound 3, percent growth inhibition at one concentration: 20%
Beside the measured number, compound 3's estimate is 8 percentage points above it, within the range that was stated.
By their numbers in this assay, from the lowest: compounds 3 and 2 (each within the scatter of the next); then compound 1.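

In this assay, going by these compounds alone, the exchange on this aromatic carbon, para to a large group, gives the first step between compounds that differ in one place: a number 3 percentage points lower from compound 2 to compound 3 (within the scatter). Here, phenyl with 6 heavy atoms and a six-membered aromatic ring of carbon only takes the place of bromo with 1 heavy atom, and the two numbers do not separate beyond the scatter, so at this position, in this pair, the larger group brings no readable difference in growth inhibition at the concentration tested. No supporting data bear on the reason for this outcome.

The compounds shown cover only bromo and phenyl at this position, so it remains open whether an amine, a carboxylic acid or a longer chain on the same aromatic carbon would give a step beyond the scatter. On these data alone, compound 1 differs from compound 2 and from compound 3 in more than one place, so which of its structural differences goes with its number also remains open.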